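Propanoyl to butanoyl on the methoxy-acid series

The compounds below may be only part of what the source reports. "The series", "measured", "known", "first", "only" and "open" are said of these compounds alone.

Measured compounds:
- compound 1 `CCCC(=O)c1ccc(OCCCCOc2ccc(F)c(C(=O)O)c2)c(C)c1O`: 56.9%
- compound 2 `Cc1c(OCCCCOc2ccc(C(=O)O)cc2Cl)ccc(C(=O)CC2CCCC2)c1O`: 27.4%
- compound 3 `CCC(=O)c1ccc(OCCCCOc2cc(C(=O)O)ccc2OC)c(C)c1O`: 62.5%

All three were run in an assay on HEK293 cells for positive allosteric modulation of metabotropic glutamate receptor 3 (Rattus norvegicus), read by thallium flux, with a stated time of 2.5 min; a higher number here means a larger maximal response, a lower number a smaller maximal response. Compound 3 stands at the high end of the numbers in hand; its gap to compound 1 lies within the scatter, so the two cannot be ordered against each other, while its gap to compound 2 lies beyond the scatter, compound 2 giving the smaller maximal response. The set is too small for any trend: compound 2 carries both a different acyl chain and a different acid part, so nothing separates those two changes.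

Compound 4 `CCCC(=O)c1ccc(OCCCCOc2cc(C(=O)O)ccc2OC)c(C)c1O` is the next member. Relative to compound 3 it differs as methyl in place of hydrogen on a saturated chain carbon, two bonds along the chain from a carbonyl carbon. The acid part with the methoxy group and the shared core are kept. Compound 1 already carries the longer acyl chain of compound 4, on a different acid part, and its value is within the scatter of compound 3, which gives no ground to expect a change beyond the scatter here. Compound 4 is therefore expected to come out close to compound 3, the step from compound 3 to compound 4 estimated at a number 2.5 percentage points lower from compound 3 to compound 4 (within the scatter). The estimate for compound 4 in this assay is 60%, with a range from 45% to 75%.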

Compound 4, largest response reached (reported as percent of maximum), in percent of the reference or control that the assay uses: 64.2%
For compound 4 the middle estimate is 4.2 percentage points below the measured one, within the range that was stated.
By their numbers in this assay, from the lowest: compound 2; then compounds 1, 3 and 4 (each within the scatter of the next).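

In this assay, within the data shown here, the pair compound 3 and compound 4 gives the first step that can be read at a single place: methyl in place of hydrogen on a saturated chain carbon, two bonds along the chain from a carbonyl carbon, gives a number 1.7 percentage points higher from compound 3 to compound 4 (within the scatter). Among these compounds, with the methoxy acid part and the shared core held fixed, the two compounds cannot be told apart by maximal response, so this position accepts the added methyl on this one acid part, a reading the earlier compounds could not give because each differed from the others in more than one place. No measured property or other supporting data bears on this result, so the step stands here as an observation alone.

Still open, on these data alone, is whether a longer chain such as pentanoyl, a branched chain such as isobutanoyl, or an amine or hydroxyl group on this same chain carbon would keep the maximal response within the scatter of compound 3. Also open, as far as these compounds go, is whether the same methyl step would read alike on a fluoro or chloro acid part.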